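The compounds below may be only part of what the source reports. "The series", "measured", "known", "first", "only" and "open" are said of these compounds alone.

Three ureas on one shared core have been tested in a functional assay on MGC-803 cells (Homo sapiens) for antiproliferative activity, read by MTT assay, with a stated time of 48 h; on this read-out higher numbers stand for weaker inhibition and lower numbers for stronger inhibition: compound 1 `O=C(Nc1cccc(CNc2nccnc2Cl)c1)Nc1cccc2ccccc12`, compound 2 `CCc1ccc(NC(=O)Nc2cccc(CNc3nccnc3Cl)c2)c(CC)c1` and compound 3 `CC(C)(C)c1ccc(NC(=O)Nc2cccc(CNc3nccnc3Cl)c2)cc1`. Compound 2 gives 6130 nM, the second highest of the three numbers. Compound 3 gives 4820 nM, which sits within the usual scatter of compound 2. Compound 1 gives 32700 nM, a higher number that lies beyond the scatter. Compound 4 `CCc1ccccc1NC(=O)Nc1cccc(CNc2nccnc2Cl)c1` is compound 2 with hydrogen in place of ethyl on an aromatic carbon. Among the compounds with values here, no measured pair shows this change, so its size is not known from the data; a modest rise in this assay is expected, close to the edge of the scatter rather than a large jump. The expected step is a 1.6-fold higher number from compound 2 to compound 4 (0.21 log units; within the scatter). Compound 4 is therefore estimated at 10000 nM, within a range from 4000 nM to 25000 nM.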

Compound 4, half-maximal inhibitory concentration: 9370 nM
For compound 4 the middle estimate is 1.1-fold (0.03 log units) above the measured one, within the range that was stated.
By their numbers in this assay, from the lowest: compounds 3, 2 and 4 (each within the scatter of the next); then compound 1.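

The earlier compounds shown here showed no step at this position; in this assay, hydrogen in place of ethyl on this aromatic carbon now gives a 1.5-fold higher number from compound 2 to compound 4 (0.18 log units; within the scatter). The two compounds therefore cannot be told apart on this read-out, with or without this ethyl. No evidence at hand bears on the reason for this result.

On these data alone, it remains open whether an amine, a carboxylic acid or a longer chain on this aromatic carbon would give a step beyond the scatter.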